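This account rests on a few compounds, and the source may have more. Where it says the series, first, only, none or still open, it means among the compounds named here.

Measured so far:
In a functional assay on HL-60 cells (Homo sapiens) for antiproliferative activity, read by MTT assay, with a stated time of 72 h (a higher number here means a weaker inhibitor, a lower number a stronger inhibitor), compound 1, `COc1cc(-c2ncnn2-c2ccc(F)cc2)cc(OC)c1OC`, gives only a limit of the assay, > 10000 nM.
In this assay compound 2, `COc1cc(-c2ncnn2-c2ccc(Cl)cc2)cc(OC)c1OC`, gives only a limit of the assay, > 10000 nM.
In this assay compound 3, `COc1cc(-n2ncnc2-c2cccc(Cl)c2)cc(OC)c1OC`, gives only a limit of the assay, > 10000 nM.

All three measured compounds sit at the limit of > 10000 nM in this assay, at which 3 of the 3 values shown sit, so no number is known for any of them. The change from compound 2 to compound 1 is fluoro in place of chloro on an aromatic carbon; its step that the two limits leave unreadable from compound 2 to compound 1 cannot be read because both values sit at the limit of > 10000 nM in this assay, at which 3 of the 3 values shown sit. The difference between the core of compound 2 and the core of compound 3 is not broken down here.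

Compound 4, `COc1cc(-n2ncnc2-c2cccc(F)c2)cc(OC)c1OC`, is not yet measured. It differs from compound 3 by fluoro in place of chloro on an aromatic carbon. This is the same kind of change as from compound 2 to compound 1, but not the same: there the place is para to a large group, here it is meta to a large group.

The expectation for compound 4 rests on compound 3, which gives > 10000 nM. The step that the limit leaves unreadable from compound 3 to compound 4 is expected to stay within the scatter, as the earlier step left no readable size. Compound 4 is expected to give 15000 nM, in a range from 5000 nM to 50000 nM, most likely again as a limit only.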

Compound 4, half-maximal inhibitory concentration: > 10000 nM
Compound 4 was reported as a limit; the forecaster's own chance of this, stated with the estimate: 85%; the middle value is on the limit's open side.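

Compound 4, like compound 3, yields only a limit, so no size can be read for the change from 3-chlorophenyl to 3-fluorophenyl between them, and all compounds shown sit at the same point: the limit of > 10000 nM in this assay, at which 4 of the 4 values shown sit.

The compounds shown leave open how 3-chlorophenyl and 3-fluorophenyl compare, and which structure in this series would give a measurable value in this assay.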